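The source may hold more compounds than are shown below. What is called first, only, known or untested is meant among the compounds shown, and "the series" means these compounds.

Compound 2 `COc1cccc(CNCCCNc2ccnc3cc(CCc4ccccc4)ccc23)c1O` is one of two measured compounds; in a physicochemical assay for acid dissociation, compound 2 gives 9.47, and compound 1 `COc1cccc(CNCCCNc2ccnc3cc(Oc4ccccc4)ccc23)c1O` gives 9.28, the two numbers lying within the scatter of each other. Among the measured compounds shown here, the only measured step is a number 0.19 log units higher from compound 1 to compound 2 (within the scatter), a change at the same aromatic carbon that left the read-out essentially unmoved. Compound 3 `COc1cccc(CNCCCNc2ccnc3cc(-c4cccc5ccccc45)ccc23)c1O` differs from compound 2 by naphthalen-1-yl in place of phenethyl on an aromatic carbon. For the measured compounds named here, since the one comparable change on that carbon gave no movement beyond the scatter, compound 3 is expected to show none either, a number 0.02 log units lower from compound 2 to compound 3 (within the scatter). The estimate for compound 3 in this assay is therefore 9.45, expected to fall between 9.15 and 9.75.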

Compound 3, acid dissociation constant: 9.47
Compound 3: middle estimate off by 0.02 log units, on the low side; the range from low to high includes it.
By their numbers in this assay, from the lowest: compounds 1, 2 and 3 (each within the scatter of the next).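

In this assay, naphthalen-1-yl, which brings two six-membered aromatic rings of carbon only, behaves like the earlier groups on this aromatic carbon, with no change at the digits printed from compound 2 to compound 3 (within the scatter) and a number 0.19 log units higher from compound 1 to compound 3 (within the scatter) as the two steps. Phenoxy, phenethyl and naphthalen-1-yl thus all sit within the scatter of one another, so the read-out has not responded to any exchange at this position so far. Nothing measured here offers an explanation for this. Going by these compounds, whether an amine or a carboxylic acid on this same carbon would shift the number remains open. So does the effect of any change elsewhere on the shared core.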